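Aryl amide to phenylsulfonyl on the shared indole core

The compounds below may be only part of what the source reports. "The series", "measured", "known", "first", "only" and "open" are said of these compounds alone.

Measured compounds:
compound 1 `CN(C(=O)CCc1ccccc1)c1ccc2[nH]c(-c3n[nH]c4ccccc34)cc2n1` — in a functional assay on A549 cells (Homo sapiens) for antiproliferative activity, read by MTT assay, with a stated time of 72 h (a higher number here means a weaker inhibitor, a lower number a stronger inhibitor), compound 1 gives 18100 nM
compound 2 `CN(C(=O)c1ccc(Br)cc1)c1ccc2[nH]c(-c3n[nH]c4ccccc34)cc2n1` — in this assay compound 2 gives 4250 nM

Within the data shown here, compound 2 stands at the lower of the two numbers in this assay, with compound 1 the only neighbour; the step of a 4.3-fold lower number from compound 1 to compound 2 (0.63 log units; beyond the scatter) separates them. Compound 3 `CN(c1ccc2[nH]c(-c3n[nH]c4ccccc34)cc2n1)S(=O)(=O)c1ccccc1` differs from compound 2 by phenylsulfonyl in place of (4-bromophenyl)carbonyl on a nitrogen on an aromatic ring. Among the measured compounds shown here, no measured step replaces a carbonyl by a sulfonyl here; the only step bears on the other side of the carbonyl. Compound 3 is therefore expected near compound 2, with a 1.4-fold higher number from compound 2 to compound 3 (0.15 log units; within the scatter) the expected step. The estimate for compound 3 is 6000 nM, ranging from 2000 nM to 20000 nM.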

Compound 3, half-maximal inhibitory concentration: 14000 nM
The estimate for compound 3 lay 2.3-fold (0.37 log units) below the measured number, within the range that was stated.
By their numbers in this assay, from the lowest: compound 2; then compounds 3 and 1 (each within the scatter of the next).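

In this assay the group on this nitrogen matters beyond the scatter, with a 3.3-fold higher number from compound 2 to compound 3 (0.52 log units; beyond the scatter), so the phenylsulfonyl does not keep the level of the (4-bromophenyl)carbonyl. With a 1.3-fold lower number from compound 1 to compound 3 (0.11 log units; within the scatter), phenylsulfonyl and phenethylcarbonyl cannot be told apart, which leaves compound 2 alone at the lowest number. Nothing measured here accounts for this.

Going by these compounds, the change swaps carbonyl for sulfonyl and removes the bromine together, so the share of each remains unknown. A phenylcarbonyl or a 4-bromophenylsulfonyl group in this place would separate the two.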